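Methoxy for hydrogen on a phenyl of compound 1

The source may report more compounds than this note shows. Statements on the series, on what has been measured and on what is new or still open speak of the compounds shown alone.

Compound 1 `COc1ccc(C2=NN(C(=O)C3COc4ccccc4O3)C(c3ccccc3)C2)cc1` gives 6310 nM in a functional assay on WM 266-4 cells (Homo sapiens) for inhibition, read by MTT assay, with a stated time of 24 h (on this read-out higher numbers stand for weaker inhibition of growth and lower numbers for stronger inhibition of growth), the highest of the three numbers. Among the compounds with values here, compound 2 `O=C(c1ccc2c(c1)OCCO2)N1N=C(c2ccc(Br)cc2)CC1c1ccc(F)cc1` gives 3260 nM there, within the scatter of compound 1, and compound 3 `COc1ccc(C2=NN(C(=O)c3ccc4c(c3)OCCO4)C(c3ccccc3)C2)cc1` gives 2370 nM; the only measured one-place step is a 2.7-fold lower number from compound 1 to compound 3 (0.43 log units; beyond the scatter), a change on the carbonyl carbon. Compound 4 `COc1ccc(C2=NN(C(=O)C3COc4ccccc4O3)C(c3ccc(OC)cc3)C2)cc1` differs from compound 1 by methoxy in place of hydrogen on an aromatic carbon. Within the data shown here, no measured step alters this phenyl alone, so nothing in this assay speaks to the change directly; the one step available, on the carbonyl carbon, was modest. The expected step is therefore a 1.1-fold lower number from compound 1 to compound 4 (0.06 log units; within the scatter), none beyond the scatter. Compound 4 is estimated at 5500 nM, with a range of 2200 nM to 14000 nM.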

Compound 4, concentration for 50% growth inhibition: 11000 nM
Estimate against measurement, compound 4: 2.0-fold (0.30 log units) below; low and high end bracket the measured number.
By their numbers in this assay, from the lowest: compounds 3, 2, 1 and 4 (each within the scatter of the next, the first and the last beyond it).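

Within the data shown here, this is the first reading at this position: in this assay, phenyl to 4-methoxyphenyl on the core of compound 1 gives a 1.7-fold higher number from compound 1 to compound 4 (0.24 log units; within the scatter), so this aromatic carbon accepts methoxy with no change beyond the scatter. The result covers one substituent on one carbonyl partner only. No evidence bearing on this result is available.

As far as these compounds go, whether an amine or a carboxylic acid on this carbon would move the number beyond the scatter remains open. So does whether methoxy reads the same alongside the carbonyl group of compound 3.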